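Swapping the Pyrimidine of Compound 2 for a Thiadiazole

The source may hold more compounds than are shown below. What is called first, only, known or untested is meant among the compounds shown, and "the series" means these compounds.

Compound 1 `CC(Oc1cccnc1Nc1cnn(C)c1)c1cccc(C(=O)NCc2ccc(OC(F)(F)F)cc2)c1` gives 8300 nM in a functional assay on NCI-H3122 cells (Homo sapiens) for antiproliferative activity, read by MTT assay, with a stated time of 48 h; a higher number here means a weaker inhibitor, a lower number a stronger inhibitor. Compound 3 `Cc1ccc(CNC(=O)c2cccc(C(C)Oc3cccnc3Nc3cnn(CC(C)(C)O)c3)c2)cc1` gives 9100 nM in this assay. Compound 2 `Cc1ccc(CNC(=O)c2cccc(C(C)Oc3cccnc3Nc3ncccn3)c2)cc1` reaches only > 100000 nM in this assay, which is a limit of the measurement rather than a number. Compound 2 thus sits at the limit of > 100000 nM in this assay, at which 1 of the 3 values shown sits. Going by the values given here, the one measured step that bears on the change is an at least 10-fold lower number from compound 2 to compound 3 (1.04 log units; beyond the scatter), where another five-membered heteroaryl replaced the pyrimidin-2-yl. Compound 4 `Cc1ccc(CNC(=O)c2cccc(C(C)Oc3cccnc3Nc3nncs3)c2)cc1` carries 1,3,4-thiadiazol-2-yl in place of pyrimidin-2-yl on a nitrogen on an aromatic ring. Because an at least 10-fold lower number from compound 2 to compound 3 (1.04 log units; beyond the scatter) was large, a drop is expected for compound 4 as well, though its size is uncertain, and compound 4 is estimated at 30000 nM, between 6000 nM and 150000 nM. The expected step is an at least 3.3-fold lower number from compound 2 to compound 4 (0.52 log units; beyond the scatter).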

Compound 4, half-maximal inhibitory concentration: 20800 nM
Compound 4: the middle estimate sits 1.4-fold (0.16 log units) above what was measured, and the stated range covers the measured number.
By their numbers in this assay, from the lowest: compounds 1 and 3 (each within the scatter of the next); then compound 4. At a limit, above all of these: compound 2.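

In this assay the pyrimidin-2-yl on a nitrogen on an aromatic ring gives way to a second replacement that also lowers the number, with an at least 4.8-fold lower number from compound 2 to compound 4 (0.68 log units; beyond the scatter) so the gain is not confined to the pyrazole of compound 3. The two replacements are not equal, with a 2.3-fold higher number from compound 3 to compound 4 (0.36 log units; beyond the scatter) as the cost of the 1,3,4-thiadiazol-2-yl against that pyrazole. Compound 2 stands at a limit, not a number: the limit of > 100000 nM in this assay, at which 1 of the 4 values shown sits. Still open, going by these compounds, is whether a methyl or an amine on the 1,3,4-thiadiazol-2-yl would shift the number, and how much of the level of compound 3 comes from its 2-hydroxy-2-methylpropyl chain.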